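The source may report more compounds than this note shows. Statements on the series, on what has been measured and on what is new or still open speak of the compounds shown alone.

In a functional assay on KB 3-1 cells (Homo sapiens) for cytotoxicity, read by MTT assay, with a stated time of 72 h (a lower number here means a stronger inhibitor, a higher number a weaker inhibitor), compound 1 `O=C1Nc2ccccc2/C1=N/NC(=S)Nc1ccc(Cl)cc1` gives 13400 nM, compound 2 `O=C1Nc2ccccc2/C1=N/NC(=S)Nc1ccc(Oc2ccccc2)cc1` gives 5720 nM and compound 3 `CC(C)c1ccc(NC(=S)N/N=C2\C(=O)Nc3ccccc32)cc1` gives 9110 nM, which places compound 3 within the scatter of both others. Compound 4 `CCCC1CCC(c2ccc(NC(=S)N/N=C3\C(=O)Nc4ccccc43)cc2)CC1` has 4-propylcyclohexyl in place of isopropyl on an aromatic carbon. For the measured compounds named here, three measured steps bear on this change: a 2.3-fold lower number from compound 1 to compound 2 (0.37 log units; beyond the scatter), a 1.5-fold lower number from compound 1 to compound 3 (0.17 log units; within the scatter) and a 1.6-fold higher number from compound 2 to compound 3 (0.20 log units; within the scatter). Only the first lies beyond the scatter, and it is modest. None tests 4-propylcyclohexyl itself, so only a small move toward a lower number is expected, possibly none beyond the scatter. The estimated step is a 1.5-fold lower number from compound 3 to compound 4 (0.18 log units; within the scatter). For compound 4 the expected value is 6000 nM, with an estimated range of 2000 nM to 15000 nM.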

Compound 4, half-maximal inhibitory concentration: 17500 nM
Compound 4: middle estimate off by 2.9-fold (0.46 log units), on the low side, outside the stated range (above it).
By their numbers in this assay, from the lowest: compounds 2, 3, 1 and 4 (each within the scatter of the next, the first and the last beyond it).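

On the aromatic carbon that carries these groups, 4-propylcyclohexyl stays within the scatter of both isopropyl and chloro in this assay, with a 1.9-fold higher number from compound 3 to compound 4 (0.28 log units; within the scatter) and a 1.3-fold higher number from compound 1 to compound 4 (0.12 log units; within the scatter). Only the comparison with phenoxy lies beyond the scatter, with a 3.1-fold higher number from compound 2 to compound 4 (0.49 log units; beyond the scatter), so a larger carbon-only group with a non-aromatic ring does not match phenoxy here. No measured evidence accounts for these steps.

As far as these compounds go, it remains open whether phenoxy's separation from 4-propylcyclohexyl depends on its ether oxygen or its aromatic ring. A plain phenyl group at this position would help to separate the two.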